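Aryl substituent swaps on the hydroxamic acid side chain

The compounds below may be only part of what the source reports. "The series", "measured", "known", "first", "only" and "open" are said of these compounds alone.

Measured so far:
compound 1 `O=C(CCC1=CCN(CCCc2ccc(Cl)cc2)C1=O)NO` — 5100 nM
compound 2 `Cc1ccccc1CCCN1CC=C(CCC(=O)NO)C1=O` — 5100 nM
compound 3 `Cc1cccc(CCCN2CC=C(CCC(=O)NO)C2=O)c1` — 5100 nM

Compound 1, in a functional assay on HCT-15 cells (Homo sapiens) for inhibition, read by sulforhodamine B assay (a lower number here means a stronger inhibitor of growth, a higher number a weaker inhibitor of growth), gives 5100 nM, and it stands level with compounds 2 and 3 at the digits shown. The steps of no change at the digits printed from compound 1 to compound 2 (within the scatter) and no change at the digits printed from compound 1 to compound 3 (within the scatter) show that exchanging the 4-chlorophenyl for a 2-methylphenyl or a 3-methylphenyl on the saturated chain carbon leaves the readout where it was; the step of no change at the digits printed from compound 2 to compound 3 (within the scatter) between the two methyl isomers is likewise flat.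

Compound 4 `CC(C)c1ccc(CCCN2CC=C(CCC(=O)NO)C2=O)cc1` is not yet measured. The change from compound 1 is isopropyl in place of chloro on an aromatic carbon. The three measured steps all bear on it, since each exchanges one aryl substituent for another on the same ring, and each was within the scatter. The expectation for the step from compound 1 to compound 4 is therefore no change beyond the scatter, no change at the digits printed from compound 1 to compound 4 (within the scatter). Compound 4 is estimated at 5100 nM, with a range from 2000 nM to 13000 nM.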

Compound 4, concentration for 50% growth inhibition: 5100 nM
For compound 4 middle estimate and measured number coincide at the digits printed; the measured number falls inside the stated range.
By their numbers in this assay, from the lowest: compounds 1, 2, 3 and 4 (each within the scatter of the next).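

In this assay, isopropyl in place of chloro on an aromatic carbon, para to a large group, gives no change at the digits printed from compound 1 to compound 4 (within the scatter). The earlier steps shown here replaced the 4-chlorophenyl with 2-methylphenyl or 3-methylphenyl, whereas this step keeps the place on the ring and changes only the group, from 1 heavy atom to 3 heavy atoms, so a group of 3 carbon atoms is tolerated here without a readable shift. Nothing measured here offers an explanation for this flat result.

The ring substituents shown are only chloro, methyl and isopropyl, so it remains open whether an amine or a carboxylic acid at this place would move the readout. Also open, on these data alone, is whether a longer chain carrying the ring would do so.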